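This account rests on a few compounds, and the source may have more. Where it says the series, first, only, none or still open, it means among the compounds named here.

Going by the values given here, in an ADME assay on HEK293 cells (Homo sapiens) for cytotoxicity, read by reporter gene assay and resazurin assay, with a stated time of 48 h (on this read-out lower numbers stand for higher toxicity in this test and higher numbers for lower toxicity in this test), compound 2 `O=C(Nc1ccc(Sc2nc3ccccc3s2)c(Cl)c1)c1ccccc1` gives 90000 nM, the only true number so far. Compound 1 `O=C(Nc1ccc(Sc2nc3ccccc3s2)c(Cl)c1)c1cc(Br)cc(Br)c1` reads > 100000 nM, which is a limit of the assay. Compound 3 `COc1ccc(Br)cc1C(=O)Nc1ccc(Sc2nc3ccccc3s2)c(Cl)c1` has 5-bromo-2-methoxyphenyl in place of phenyl on a carbonyl carbon. Among the compounds with values here, one measured step bears on this, a change at the same carbonyl carbon: an at least 1.1-fold lower number from compound 1 to compound 2 (0.04 log units; that floor lies within the scatter). Within the data shown here, with only that small step as a guide, no step beyond the scatter is expected in this assay. The expected step is no change at the digits printed from compound 2 to compound 3 (within the scatter). Compound 3 is estimated at 90000 nM, with a range of 40000 nM to 100000 nM.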

Compound 3, half-maximal cytotoxic concentration: > 100000 nM
Compound 3 was reported as a limit (the forecaster's own chance of this, stated with the estimate: 45%); middle value at least 1.1-fold (0.04 log units) from the limit.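

At the carbonyl carbon, 5-bromo-2-methoxyphenyl in place of phenyl gives an at least 1.1-fold higher number from compound 2 to compound 3 (0.04 log units; that floor lies within the scatter) in this assay, so this larger group, which adds a hydrogen-bond acceptor, brings no step beyond the scatter. The step between compound 1 and compound 3 cannot be read, since both values are limits. How much the groups at this position differ stays hidden because the values sit at one limit: the limit of > 100000 nM in this assay, at which 2 of the 3 values shown sit.

Still open, from the compounds shown here alone, is whether an amine or a carboxylic acid in place of phenyl on the carbonyl carbon would give a clearly lower number.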